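Changing the Ring on the Sulfonyl Sulfur of Compound 1

This account rests on a few compounds, and the source may have more. Where it says the series, first, only, none or still open, it means among the compounds named here.

Of the compounds shown here, three sharing one core have been measured in an ADME assay on microsomes from liver (Homo sapiens) for metabolic stability, tested at 2.5 uM; on this read-out lower numbers stand for slow clearance and higher numbers for fast clearance. Compound 1 `O=S(=O)(c1cc(Cl)cc(Cl)c1)c1cnc2c(F)cccc2c1-c1cccc(Cl)c1` gives 1.2 mL/min, the second highest of the three numbers. Compound 2 `COc1cccc(-c2c(S(=O)(=O)c3cc(Cl)cc(Cl)c3)cnc3c(F)cccc23)c1` gives 2.31 mL/min, and compound 3 `O=S(=O)(c1cc(Cl)cc(Cl)c1)c1cnc2c(F)cccc2c1-c1ccc(Cl)cc1` gives 0.78 mL/min. The step of a 1.9-fold higher number from compound 1 to compound 2 (0.28 log units; within the scatter) and the step of a 1.5-fold lower number from compound 1 to compound 3 (0.19 log units; within the scatter) both stay within the scatter, while a 3.0-fold lower number from compound 2 to compound 3 (0.47 log units; beyond the scatter) is modest but beyond it. All three of these changes concern the ring attached to the shared core, not the ring on the sulfonyl sulfur.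

Compound 4 `Cc1ccc(S(=O)(=O)c2cnc3c(F)cccc3c2-c2cccc(Cl)c2)cc1F` has not yet been measured. It differs from compound 1 in one place: 3-fluoro-4-methylphenyl in place of 3,5-dichlorophenyl on a sulfonyl sulfur. Among the measured compounds shown here, none of the measured steps touches the ring on the sulfonyl sulfur, so the data give no direct guide for this change. For the measured compounds named here, the only nearby information is that swaps on the other ring moved the numbers at most modestly. The step of a 1.3-fold higher number from compound 1 to compound 4 (0.10 log units; within the scatter) is therefore expected to stay close to what repeated measurements would show, though with more uncertainty than usual. For compound 4 in this assay the expected value is 1.5 mL/min, within a range from 0.6 mL/min to 4 mL/min.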

Compound 4, intrinsic clearance in a liver preparation (reported as CLH), per the amount of preparation that the assay uses: 3.18 mL/min
Compound 4: the middle estimate sits 2.1-fold (0.33 log units) below what was measured; the range from low to high includes it.
By their numbers in this assay, from the lowest: compounds 3, 1, 2 and 4 (each within the scatter of the next, the first and the last beyond it).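

The ring on the sulfonyl sulfur is not a silent position in this assay: 3-fluoro-4-methylphenyl in place of 3,5-dichlorophenyl gives a 2.7-fold higher number from compound 1 to compound 4 (0.42 log units; beyond the scatter). Among the compounds shown here, this is the only measured change at this position, and it lies beyond the scatter, whereas the swaps on the other ring, from compound 1 to compound 2 and from compound 1 to compound 3, stayed within it. Nothing in the data at hand explains this step.

With a single change here, the compounds shown cannot separate the effect of removing the two chloro groups from that of adding the fluoro and methyl groups. As far as these compounds go, it also stays open whether a plain phenyl, or a phenyl bearing an amine or a carboxylic acid, on the sulfonyl sulfur would sit nearer compound 1 or compound 4.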